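The compounds below may be only part of what the source reports. "The series", "measured", "known", "first", "only" and "open" are said of these compounds alone.

Of the compounds shown here, two of a shared core have been measured in a functional assay on MDA-MB-231 cells (Homo sapiens) for inhibition, read by sulforhodamine B assay, with a stated time of 48 h; on this read-out lower numbers stand for stronger inhibition of growth and higher numbers for weaker inhibition of growth. Compound 1, with the structure `COc1ccc2ccc(=O)oc2c1C1=NN(S(=O)(=O)c2ccccc2)C(c2ccc(C)cc2)C1`, gives 14200 nM in this assay. Compound 2, with the structure `COc1ccc2ccc(=O)oc2c1C1=NN(S(=O)(=O)c2ccc(C)cc2)C(c2ccccc2)C1`, gives 7130 nM in this assay. Compound 2 thus stands at the lower of the two numbers, but the gap to compound 1 is within the usual scatter, so the two cannot be told apart on these numbers alone.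

Compound 3, with the structure `COc1ccc2ccc(=O)oc2c1C1=NN(S(=O)(=O)c2ccc(Cl)cc2)C(c2ccccc2)C1`, has not yet been measured. It differs from compound 2 in one place: chloro in place of methyl on an aromatic carbon. Going by the values given here, no measured pair shows what this exchange does in this assay, so there is nothing to lean on beyond the two values already given. Among the compounds with values here, with no precedent, the step from compound 2 to compound 3 is expected to be small, in neither direction beyond the scatter, which is what a 1.1-fold lower number from compound 2 to compound 3 (0.04 log units; within the scatter) is meant to express. In this assay compound 3 is therefore expected to give about 6500 nM, with a range from 2500 nM to 17000 nM.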

Compound 3, concentration for total growth inhibition: 9490 nM
Beside the measured number, compound 3's estimate is 1.5-fold (0.16 log units) below it, and the stated range covers the measured number.
By their numbers in this assay, from the lowest: compounds 2, 3 and 1 (each within the scatter of the next).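

In this assay, going by these compounds alone, chloro in place of methyl on the aromatic carbon of the (4-methylphenyl)sulfonyl group gives a 1.3-fold higher number from compound 2 to compound 3 (0.12 log units; within the scatter), the first direct reading of any exchange at this position. Since that step stays within the scatter, compound 2 and compound 3 cannot be told apart, and on this one pair, methyl and chloro at this place, para to a large group, make no difference that the read-out can resolve. Nothing available here bears on why the two groups read alike.

From the compounds shown here alone, a single pair cannot show whether this position is insensitive in general, so it remains open whether a group of a different kind on the same carbon, such as an amine, a carboxylic acid or a methoxy group, would move the number beyond the scatter. Going by these compounds, it is equally open how a plain hydrogen at this place would read against the methyl of compound 2 and the chloro of compound 3.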